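Extending a Chain by One Carbon on a New Core

The source may hold more compounds than are shown below. What is called first, only, known or untested is meant among the compounds shown, and "the series" means these compounds.

Compound 1 `CCCCNS(=O)(=O)c1ccc(Nc2ncc3c(n2)N(C2CCCC2)[C@H](CC)C(=O)N3C)cc1`: 225 nM
Compound 2 `CCCNS(=O)(=O)c1ccc(Nc2ncc3c(n2)N(C2CCCC2)[C@H](CC)C(=O)N3C)cc1`: 278 nM
Compound 3 `CCCNC(=O)c1ccc2c(ccn2-c2ncc3c(n2)N(c2ccn(C)n2)C(CC)C(=O)N3C)c1`: 7280 nM

All three were tested in a functional assay on Huh-7 cells (Homo sapiens) for antiproliferative activity, read by CCK-8 assay, with a stated time of 72 h; on this read-out higher numbers stand for weaker inhibition of growth and lower numbers for stronger inhibition of growth. Compounds 1 and 2 share one core and differ only in the length of a chain on a sulfonamide: the change from compound 2 to compound 1 is methyl in place of hydrogen on a saturated chain carbon, three bonds along the chain from a sulfonamide nitrogen, and the step that went with it, a 1.2-fold lower number from compound 2 to compound 1 (0.09 log units; within the scatter), lies within the scatter of the measurement. Compound 3 is built on a different core; how the two cores differ is not broken down here, and its number in this assay stands far above both of the others. Compound 4 `CCCCNC(=O)c1ccc2c(ccn2-c2ncc3c(n2)N(c2ccn(C)n2)C(CC)C(=O)N3C)c1` has the core of compound 3 with the change (methyl in place of hydrogen on a saturated chain carbon, three bonds along the chain from an amide-type nitrogen). For the measured compounds named here, this is the same kind of change as the one from compound 2 to compound 1, though there the chain hangs from a sulfonamide nitrogen and here from an amide-type nitrogen. For compound 4 a similarly small step is expected, a 1.2-fold lower number from compound 3 to compound 4 (0.07 log units; within the scatter), because the step of a 1.2-fold lower number from compound 2 to compound 1 (0.09 log units; within the scatter) stayed within the scatter. Compound 4 is therefore expected to give about 6200 nM in this assay, most likely between 2500 nM and 15000 nM.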

Compound 4, concentration for 50% growth inhibition: 8670 nM
The estimate for compound 4 lay 1.4-fold (0.15 log units) below the measured number; low and high end bracket the measured number.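

In this assay the change from propyl to butyl on the core of compound 3 gave a 1.2-fold higher number from compound 3 to compound 4 (0.08 log units; within the scatter) and so left the number unchanged as far as this measurement can tell. The same change on the other core gave a step that cannot be told apart from this one: the same change on two cores in this assay, a 1.2-fold lower number (0.09 log units; within the scatter) from compound 2 to compound 1 and a 1.2-fold higher number (0.08 log units; within the scatter) from compound 3 to compound 4, 1.5-fold (0.17 log units) apart, within the scatter of two such steps

For the compounds shown here, in these two pairs, then, adding one carbon to the chain carried over from one core to the other with no measurable effect on either, though this rests on only two pairs, the chain hangs from a sulfonamide nitrogen in one and from an amide-type nitrogen in the other, and steps this small cannot separate a slight real effect from none.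

Open, going by these compounds, is whether a longer chain such as pentyl, a branched chain, or a chain ending in an amine or a carboxylic acid would behave the same way on either core. Also open, on these data alone, is which of the several differences between compound 2 and compound 3 goes with the wide gap in their numbers.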